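From 2-chlorophenyl to 3-methoxyphenyl on a shared core

This account rests on a few compounds, and the source may have more. Where it says the series, first, only, none or still open, it means among the compounds named here.

Compound 1 `O=S1(=O)C=C(Sc2nnc(-c3cccnc3)o2)c2ccccc21`: 14000 nM
Compound 2 `O=S1(=O)C=C(Sc2nnc(C3CCCCC3)o2)c2ccccc21`: 15000 nM
Compound 3 `O=S1(=O)C=C(Sc2nnc(-c3ccccc3Cl)o2)c2ccccc21`: 25000 nM

These values come from an ADME assay on HepG2 cells (Homo sapiens) for cytotoxicity, read by fluorescence and resazurin assay, with a stated time of 24 h; on this read-out higher numbers stand for lower toxicity in this test and lower numbers for higher toxicity in this test. Compound 3 stands at 25000 nM, within the usual scatter of compound 1 and compound 2, so the three cannot be ranked.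

Compound 4 `COc1cccc(-c2nnc(SC3=CS(=O)(=O)c4ccccc43)o2)c1` has not been measured yet. It keeps the shared core and has 3-methoxyphenyl in place of 2-chlorophenyl on an aromatic carbon of the five-membered aromatic ring: 3-methoxyphenyl in place of 2-chlorophenyl on an aromatic carbon.

The measured steps at this same place are the best guide. They are a 1.8-fold higher number from compound 1 to compound 3 (0.25 log units; within the scatter), a 1.7-fold higher number from compound 2 to compound 3 (0.22 log units; within the scatter) and a 1.1-fold higher number from compound 1 to compound 2 (0.03 log units; within the scatter). All three stay within the scatter, although the groups exchanged differ widely. None of these compounds carries 3-methoxyphenyl, however, so direct evidence is lacking.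

No change beyond the scatter is therefore expected in this assay, and the estimated step is a 1.4-fold lower number from compound 3 to compound 4 (0.14 log units; within the scatter). For compound 4 the estimated value is 18000 nM, with an expected range of 9000 nM to 35000 nM.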

Compound 4, half-maximal cytotoxic concentration: 20000 nM
Estimate against measurement, compound 4: 1.1-fold (0.05 log units) below, within the range that was stated.
By their numbers in this assay, from the lowest: compounds 1, 2, 4 and 3 (each within the scatter of the next).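

In this assay, 3-methoxyphenyl brings an oxygen and a hydrogen-bond acceptor that 2-chlorophenyl lacks, yet the result is a 1.3-fold lower number from compound 3 to compound 4 (0.10 log units; within the scatter). The comparisons with the other two groups, a 1.3-fold higher number from compound 2 to compound 4 (0.12 log units; within the scatter) and a 1.4-fold higher number from compound 1 to compound 4 (0.15 log units; within the scatter), also stay within the scatter, so all four compounds remain unranked and this position has now tolerated a fourth group with no clear change in the number. Nothing available explains this lack of change.

Each group shown at this position is a ring, so it remains open whether an open-chain group such as a longer alkyl chain, or a group such as an amine or a carboxylic acid, would stay within the same band. Also open, on these data alone, is whether a change to the shared core would move the number beyond the scatter.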